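Cytotoxicity limit and the swap to compound 3

The compounds below may be only part of what the source reports. "The series", "measured", "known", "first", "only" and "open" are said of these compounds alone.

- compound 1 `Cc1ccc(CNc2nc(N)nc3ccn(Cc4ccccn4)c23)nc1`: > 24000 nM (a limit)
- compound 2 `Cc1cnc(CNc2nc(N)nc3ccn(Cc4ccccn4)c23)o1`: > 24000 nM (a limit)

In an ADME assay on HEK293 cells (Homo sapiens) for cytotoxicity, read by ATP content, with a stated time of 6 h (a higher number here means that more compound is tolerated, a lower number that less compound is tolerated), compound 2 stands at > 24000 nM which is a limit and not a number. Compound 3 `Nc1nc(NCc2ccon2)c2c(ccn2Cc2ccccn2)n1` differs from compound 2 by one change: 1,2-oxazol-3-yl in place of 5-methyl-1,3-oxazol-2-yl on a saturated chain carbon bound to a nitrogen on an aromatic ring is all that separates them. Among the compounds with values here, the only measured step, a step that the two limits leave unreadable from compound 1 to compound 2, changes the group at this same place, and its size cannot be read. No step beyond the usual scatter is expected in this assay because the limit of > 24000 nM in this assay, at which 2 of the 2 values shown sit, holds for compound 1 and compound 2 alike. The estimated a number no higher from compound 2 to compound 3 (the limit leaves the size open) has no expected direction. Compound 3 is expected at 24000 nM with an estimated range from 12000 nM to 48000 nM and another limit is the likely report.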

Compound 3, half-maximal cytotoxic concentration: > 24000 nM
Compound 3: only a limit was reported; the forecaster's own chance of this, stated with the estimate: 85%; the middle value sits exactly at the limit.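

In this assay compound 3 gives > 24000 nM, which is a limit. Within the data shown here, no step among compound 1, compound 2 and compound 3 can be read: the limit of > 24000 nM in this assay, at which 3 of the 3 values shown sit. The compounds shown leave open at what concentration any of them becomes cytotoxic, and whether the group on the saturated chain carbon changes that concentration.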